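Cytotoxicity of a deoxyuridine pair in leukaemia cells

A few compounds are considered here, and "the series" means these few. Any claim that something is new, unique, unknown or untested is made for them only; others in the source may bear on it.

Measured compounds:
compound 1 `O=c1[nH]cnc2c1nnn2C1C[C@H](CO)[C@@H](CO)[C@@H]1CO` gives > 200000 nM
compound 2 `O=c1[nH]c(=O)n([C@H]2C[C@H](O)[C@@H](CO)O2)cc1/C=N/O` gives 15500 nM

In an ADME assay on L1210/0 cells (Mus musculus) for cytotoxicity, with a stated time of 48 h (a lower number here means a stronger inhibitor, a higher number a weaker inhibitor), compound 1 reaches only a limit, > 200000 nM, and no number. In this assay compound 2 gives 15500 nM, the only number shown. The other value, that of compound 1, is the limit of > 200000 nM in this assay, at which 1 of the 2 values shown sits. Compound 3 `CCCC#Cc1cn([C@H]2C[C@H](O)[C@@H](CO)O2)c(=O)[nH]c1=O` is not yet measured in this assay. It differs from compound 2 in one place: a group of 5 heavy atoms (5 carbon; no ring) in place of a group of 3 heavy atoms (1 carbon, 1 nitrogen, 1 oxygen; no ring), on an aromatic carbon. For the measured compounds named here, no pair of measured compounds differing in one place is available, so the size of this step cannot be read from the data. Compound 3 is expected to lie within the range of the scatter around compound 2 or somewhat weaker, which is the step of a 1.9-fold higher number from compound 2 to compound 3 (0.29 log units; within the scatter). Compound 3 is therefore estimated at 30000 nM, between 5000 nM and 200000 nM.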

Compound 3, half-maximal inhibitory concentration: > 200000 nM
Compound 3: no number, only a limit; the forecaster's own chance of this, stated with the estimate: 20%; middle value at least 6.6-fold (0.82 log units) from the limit.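

In this assay, replacing the group of compound 2 with pent-1-yn-1-yl on this aromatic carbon gives an at least 12-fold higher number from compound 2 to compound 3 (1.11 log units; beyond the scatter), so the readout at this position depends strongly on the group it carries. The reading for compound 3 is a limit and not a number, so the step gives only a minimum size. With this result, limit readings make up most of the values shown: the limit of > 200000 nM in this assay, at which 2 of the 3 values shown sit.

The compounds shown leave open which feature of the change accounts for the step: the loss of the hydrogen-bond donor and acceptors, or the entry of the triple bond and the chain. They also leave open whether an ethynyl group, a saturated pentyl chain or a hydroxymethyl group on this carbon would read close to compound 2 or reach the limit.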